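The source may hold more compounds than are shown below. What is called first, only, known or untested is meant among the compounds shown, and "the series" means these compounds.

In a functional assay on A549 cells (Homo sapiens) for cytotoxicity, read by MTT assay, with a stated time of 24 h (a higher number here means a weaker inhibitor, a lower number a stronger inhibitor), compound 1 (`C/C(=N\NC(=O)/C(C#N)=C/c1ccccc1)c1c(O)c2ccc(O)cc2oc1=O`) gives 14800 nM and compound 2 (`C/C(=N\NC(=O)/C(C#N)=C/c1ccc(Br)cc1)c1c(O)c2ccc(O)cc2oc1=O`) gives 11400 nM so compound 2 stands level with compound 1 within the usual scatter. Compound 3 (`C/C(=N\NC(=O)/C(C#N)=C/c1ccccc1[N+](=O)[O-])c1c(O)c2ccc(O)cc2oc1=O`) has not yet been measured. It carries 2-nitrophenyl in place of 4-bromophenyl on a double-bonded chain carbon bound to a double-bonded chain carbon. Within the data shown here, only one measured step bears on this change, and only loosely, since it swaps bromo for hydrogen on an aromatic carbon and involves no nitro group. Among the measured compounds shown here, that step (a 1.3-fold lower number from compound 1 to compound 2 (0.11 log units; within the scatter)) is small, and no measured compound yet carries the entering group. No shift beyond the scatter is therefore expected in this assay and the estimated step (a 1.1-fold higher number from compound 2 to compound 3 (0.02 log units; within the scatter)) reflects that. Compound 3 is expected to give about 12000 nM (estimated range 5000 nM to 28000 nM).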

Compound 3, half-maximal inhibitory concentration: 11400 nM
The estimate for compound 3 lay 1.1-fold (0.02 log units) above the measured number, within the range that was stated.
By their numbers in this assay, from the lowest: compounds 2, 3 and 1 (each within the scatter of the next).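

In this assay the exchange of 4-bromophenyl for 2-nitrophenyl on a double-bonded chain carbon bound to a double-bonded chain carbon gives no change at the digits printed from compound 2 to compound 3 (within the scatter) although the two groups differ in their atoms and in their hydrogen-bond acceptors. Adding the nitro group to the unsubstituted compound gives a 1.3-fold lower number from compound 1 to compound 3 (0.11 log units; within the scatter) so this second substituent on the phenyl ring, like bromo before it, stays within the scatter of the unsubstituted compound. Nothing measured here accounts for this flat result.

Still open, as far as these compounds go, is whether an amine or a carboxylic acid on this phenyl ring would move the number beyond the scatter. Also open, from the compounds shown here alone, is whether 2-bromophenyl would read the same as 4-bromophenyl, which would show if the place on the ring matters at all.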